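Compound 4 and a Carboxypyridinyl Arm

The source may report more compounds than this note shows. Statements on the series, on what has been measured and on what is new or still open speak of the compounds shown alone.

Compound 1 `OC[C@@H](O[C@H]1CCCN(Cc2ccccc2Cc2nnco2)[C@H]1c1ccccc1)c1cc(Cl)cc(Cl)c1`: 3700 nM
Compound 2 `O=C(O)c1ccc(CN2CCC[C@H](OCc3cc(Cl)cc(Cl)c3)[C@@H]2c2ccccc2)cn1`: a limit, > 200000 nM
Compound 3 `COc1cc(C(=O)O)ccc1CN1CCC[C@H](OCc2cc(Cl)cc(Cl)c2)[C@@H]1c1ccccc1`: 62000 nM

In an assay on isolated protein for activation of cGMP-dependent protein kinase 1 (Homo sapiens), read by ADP-Glo, with stated times of 120 min and 40 min (a lower number here means that less compound is needed, a higher number that more compound is needed for the effect), compound 1 holds the lowest of the two numbers shown, well below compound 3. Compound 2 reaches only the assay limit (the limit of > 200000 nM in this assay, at which 1 of the 3 values shown sits). Compound 4 `O=C(O)c1cncc(CN2CCC[C@H](O[C@H](CO)c3cc(Cl)cc(Cl)c3)[C@@H]2c2ccccc2)c1` differs from compound 1 in one place: a group of 9 heavy atoms (6 carbon, 1 nitrogen, 2 oxygen; one six-membered aromatic ring with 1 hetero atom) in place of a group of 12 heavy atoms (9 carbon, 2 nitrogen, 1 oxygen; one five-membered aromatic ring with 3 hetero atoms, one six-membered aromatic ring of carbon only), on a saturated chain carbon bound to an amine nitrogen in a ring. For the measured compounds named here, no measured step covers this exact exchange. Going by the values given here, the only step on the same position, an at least 3.2-fold lower number from compound 2 to compound 3 (0.50 log units; beyond the scatter), swaps one carboxy-bearing aryl for another, and both of those compounds sit far above compound 1 with their carboxy-aryl arms. A clearly higher number is therefore expected for compound 4, with the step of a 5.4-fold higher number from compound 1 to compound 4 (0.73 log units; beyond the scatter) estimated. Compound 4 is expected near 20000 nM, between 5000 nM and 100000 nM.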

Compound 4, half-maximal effective concentration: 34000 nM
The estimate for compound 4 lay 1.7-fold (0.23 log units) below the measured number; the measured number falls inside the stated range.
By their numbers in this assay, from the lowest: compound 1; then compounds 4 and 3 (each within the scatter of the next). At a limit, above all of these: compound 2.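

For the compounds shown here, compound 4 gives the first step at this position that starts from an arm without a carboxy group: on a saturated chain carbon bound to an amine nitrogen in a ring, 5-carboxypyridin-3-yl in place of the larger group of compound 1 brings a 9.2-fold higher number from compound 1 to compound 4 (0.96 log units; beyond the scatter) on an otherwise shared core. Compounds 2 and 3 compared only one carboxy-bearing aryl with another, so they could not show this. Nothing measured here explains the change.

As far as these compounds go, it remains open whether the carboxylic acid or the pyridine ring accounts for the step. Also open, from the compounds shown here alone, is how a methyl ester or an amide on that ring would read.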